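The compounds below may be only part of what the source reports. "The series", "measured", "known", "first", "only" and "open" are said of these compounds alone.

Compound 1 `O=C(Nc1ccc(I)cc1F)c1ccccc1OCc1ccc(F)cc1F` carries a 2,4-difluorobenzyl ether on the aromatic ring of the amide, and in an ADME assay on RAW264.7 cells (Mus musculus) for cytotoxicity, read by MTT assay, with a stated time of 24 h (a higher number here means that more compound is tolerated, a lower number that less compound is tolerated), compound 1 gives 32600 nM. Compound 2 `COc1ccc(C(=O)Nc2ccc(I)cc2F)c(O)c1` instead bears a hydroxyl at that position together with a methoxy group, and in this assay compound 2 gives 27600 nM. Compound 3 `COc1ccc(C(=O)Nc2ccc(I)cc2F)c(OC)c1` is the methyl ether of compound 2. For compound 3 this assay reports only a limit, > 40000 nM. The step of an at least 1.4-fold higher number from compound 2 to compound 3 (0.16 log units; that floor lies within the scatter) is therefore known only as a floor, and it sits among the cases described by the limit of > 40000 nM in this assay, at which 1 of the 3 values shown sits.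

Compound 4 `COc1ccc(C(=O)Nc2ccc(I)cc2F)c(OCc2ccc(F)cc2F)c1` is the next compound, and it differs from compound 3 by 2,4-difluorophenyl in place of hydrogen on a saturated chain carbon bound to an oxygen on an aromatic ring. Going by the values given here, no measured step matches this change exactly. The pair that comes closest is compound 1 against compound 3: compound 1 carries the same 2,4-difluorobenzyl ether, and its value in this assay lies close to the limit reported for compound 3, though the two also differ in the methoxy group. On that basis compound 4 is expected to stay within the scatter of compound 3, with the step of an at least 1.1-fold lower number from compound 3 to compound 4 (0.05 log units; that floor lies within the scatter) estimated to be small. For compound 4 the expected value in this assay is 35000 nM, with a range from 15000 nM to 80000 nM.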

Compound 4, half-maximal cytotoxic concentration: 36800 nM
For compound 4 the middle estimate is 1.1-fold (0.02 log units) below the measured one; the measured number falls inside the stated range.
By their numbers in this assay, from the lowest: compounds 2, 1 and 4 (each within the scatter of the next). At a limit, above all of these: compound 3.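

The 2,4-difluorobenzyl ether on this oxygen, set against the free hydroxyl, gives a 1.3-fold higher number from compound 2 to compound 4 (0.12 log units; within the scatter), and methoxy in place of hydrogen on the aromatic carbon gives a 1.1-fold higher number from compound 1 to compound 4 (0.05 log units; within the scatter), so neither change moves the number in this assay beyond the scatter. Against the methyl ether the comparison is less firm: for compound 3 the assay gives only a limit, > 40000 nM. The change from methyl to 2,4-difluorobenzyl is therefore known only as a floor, an at least 1.0-fold lower number from compound 3 to compound 4 (0.03 log units; that floor lies within the scatter), and its true size cannot be read: the limit of > 40000 nM in this assay, at which 1 of the 4 values shown sits.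

The compounds shown carry only hydroxyl, methyl or 2,4-difluorobenzyl on this oxygen, so they leave open whether a longer chain there, or an amine or a carboxylic acid on the benzyl ring, would take the number in this assay beyond the scatter. They also leave open how far compound 3 actually stands from the other three, and so whether the methyl ether differs from the 2,4-difluorobenzyl ether at all.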